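This account rests on a few compounds, and the source may have more. Where it says the series, first, only, none or still open, it means among the compounds named here.

The series shares the core of compound 1 `N#Cc1cc(C#N)cc(-n2nnc(-c3ccccn3)n2)c1`, which in an assay on cell membranes for binding affinity to metabotropic glutamate receptor 5 (Rattus norvegicus) (on this read-out lower numbers stand for stronger inhibition and higher numbers for weaker inhibition), gives 18 nM. Compound 2 `N#Cc1cc(-n2nnc(-c3ccccn3)n2)cc([N+](=O)[O-])c1` gives 42 nM in this assay, a step of a 2.3-fold higher number from compound 1 to compound 2 (0.37 log units; beyond the scatter). Compound 3 `N#Cc1cc(OCC2CC2)cc(-n2nnc(-c3ccccn3)n2)c1` gives 271 nM in this assay, the highest number of the three and hence the weakest inhibition shown so far: a 15-fold higher number from compound 1 to compound 3 (1.18 log units; beyond the scatter) and a 6.5-fold higher number from compound 2 to compound 3 (0.81 log units; beyond the scatter). Compound 4 `N#Cc1cc(OCc2ccccc2)cc(-n2nnc(-c3ccccn3)n2)c1` has not been measured; against compound 3 the change is phenyl in place of cyclopropyl on a saturated chain carbon bound to an oxygen on an aromatic ring. Among the measured compounds shown here, all three measured steps exchange the group standing directly on the aromatic carbon, and none alters the cyclopropylmethoxy group itself, so no measured step bears directly on this change; the numbers give no ground for a shift in either direction. In this assay a step of a 1.1-fold higher number from compound 3 to compound 4 (0.04 log units; within the scatter) is therefore expected, with the range kept wide. Compound 4 is estimated at 300 nM in this assay, between 100 nM and 900 nM.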

Compound 4, inhibition constant: > 600 nM
Compound 4: a limit, no number; the forecaster's own chance of this, stated with the estimate: 5%; at least 2.0-fold (0.30 log units) between middle value and limit.
By their numbers in this assay, from the lowest: compound 1; then compound 2; then compound 3. At a limit, above all of these: compound 4.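

In this assay compound 4 is read only as a limit of the assay, not as a number: the limit of > 600 nM in this assay, at which 1 of the 4 values shown sits.

Even so, the cyclopropylmethoxy group proves sensitive to change at the saturated chain carbon bound to an oxygen on an aromatic ring, the only step here that alters that group itself: an at least 2.2-fold higher number from compound 3 to compound 4 (0.34 log units; beyond the scatter). Benzyloxy on the aromatic carbon also gives an at least 14-fold higher number from compound 2 to compound 4 (1.15 log units; beyond the scatter) and an at least 33-fold higher number from compound 1 to compound 4 (1.52 log units; beyond the scatter), so across these four compounds the nitrile of compound 1 gives the strongest inhibition and the benzyloxy of compound 4 the weakest.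

As far as these compounds go, how far compound 4 lies past its limit stays open, so the phenyl step has a lower bound only. From the compounds shown here alone, whether a methoxy group or an amine on that aromatic carbon would bring the number back towards that of compound 1 also stays open.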